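A few compounds are considered here, and "the series" means these few. Any claim that something is new, unique, unknown or untested is made for them only; others in the source may bear on it.

Measured so far in a functional assay on A549 cells (Homo sapiens) for cytotoxicity, read by sulforhodamine B assay, with a stated time of 72 h; on this read-out lower numbers stand for stronger inhibition and higher numbers for weaker inhibition:
Compound 1 `Nc1sc(-c2ccc(Cl)cc2)c(-c2ccc(Cl)cc2)c1C(=S)NC1CC1` gives 8280 nM.
Compound 2 `Nc1sc(-c2ccc(Cl)cc2)c(-c2ccc(Cl)cc2)c1C(=S)NC1CCCCC1` gives 7410 nM.
Compound 3 `Clc1ccc(-c2sc3ncnc(NC4CC4)c3c2-c2ccc(Cl)cc2)cc1` gives 42800 nM.

Compound 2 arises from compound 1 by one change, (cyclohexyl in place of cyclopropyl on an amide-type nitrogen), and this step is a 1.1-fold lower number from compound 1 to compound 2 (0.05 log units; within the scatter). Compound 3 has a different core from compound 1; how the two cores differ is not broken down here. Compound 4 `Clc1ccc(-c2sc3ncnc(NC4CCCCC4)c3c2-c2ccc(Cl)cc2)cc1` is compound 3 with the same kind of change, (cyclohexyl in place of cyclopropyl on a nitrogen on an aromatic ring). It is not the same change, since the place differs: in compound 1 the nitrogen is amide-type, its other neighbour a thiocarbonyl carbon, while in compound 3 it is a nitrogen on an aromatic ring, its other neighbour an aromatic carbon. Because the earlier step was a 1.1-fold lower number from compound 1 to compound 2 (0.05 log units; within the scatter), a similarly small step, a 1.1-fold lower number from compound 3 to compound 4 (0.05 log units; within the scatter), is expected here, though the other core adds uncertainty. Compound 4 is therefore estimated at 38000 nM in this assay, with a range from 15000 nM to 95000 nM.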

Compound 4, half-maximal inhibitory concentration: > 50000 nM
Compound 4: a limit, no number; the forecaster's own chance of this, stated with the estimate: 12%; middle value at least 1.3-fold (0.11 log units) from the limit.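

In this assay compound 4 gives > 50000 nM and that value is a limit of the assay, not a number. Cyclohexyl in place of cyclopropyl on a nitrogen on an aromatic ring thus gives an at least 1.1-fold higher number from compound 3 to compound 4 (0.06 log units; that floor lies within the scatter) as a floor only, so the true size of this step stays unknown. The comparison therefore does not show whether this change carries from one core to the other with the same effect, nor that it fails to carry: the same change on two cores in this assay, a 1.1-fold lower number (0.05 log units; within the scatter) from compound 1 to compound 2 and an at least 1.1-fold higher number (0.06 log units; that floor lies within the scatter) from compound 3 to compound 4; the limit leaves it open whether they differ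

All the groups on this nitrogen in the compounds shown are rings of carbon only. On these data alone, it remains open how an open-chain group such as butyl, or a ring carrying a hydroxyl or an amine, would read on either core in this assay and whether any such compound on the core of compound 3 would give a number rather than a limit.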